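This account rests on a few compounds, and the source may have more. Where it says the series, first, only, none or still open, it means among the compounds named here.

Measured so far:
compound 1, `CCOC(=O)C1C(=O)C=C(Nc2cccc(N3CCN(C)CC3)c2)CC1C`: 3.05 in a physicochemical assay for lipophilicity; on this read-out higher numbers stand for higher lipophilicity and lower numbers for lower lipophilicity
compound 2, `COC(=O)C1C(=O)C=C(Nc2ccccc2N2CCN(C)CC2)CC1c1ccccc1`: 3.97 in this assay
compound 3, `CCOC(=O)C1C(=O)C=C(Nc2cccc(N3CCN(C)CC3)c2)CC1c1ccccc1`: 4.37 in this assay

Compound 2 and compound 3 share much of their make-up, but the difference between the two cores is not broken down here; compound 3 gives the higher of the two numbers. Compound 3 and compound 1 differ in one place only: methyl in place of phenyl on a saturated ring carbon. That single change gave a number 1.32 log units lower from compound 3 to compound 1 (beyond the scatter).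

Compound 4, `COC(=O)C1C(=O)C=C(Nc2ccccc2N2CCN(C)CC2)CC1C`, is still to be measured in this assay. It stands to compound 2 as compound 1 stands to compound 3: methyl in place of phenyl on a saturated ring carbon. The surroundings are not identical, though: in compound 3 the saturated ring carbon sits next to the ring atom that bears an ethoxycarbonyl group, in compound 2 next to the ring atom that bears a methoxycarbonyl group, so this is the same kind of change rather than the same one. A step of about a number 1.32 log units lower from compound 2 to compound 4 (beyond the scatter) is expected because the earlier one was a number 1.32 log units lower from compound 3 to compound 1 (beyond the scatter). Compound 4 is therefore estimated at 2.65, most likely between 2.2 and 3.1.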

Compound 4, partition coefficient: 2.65
Compound 4: middle estimate and measured number agree at the digits printed; low and high end bracket the measured number.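

Methyl in place of phenyl on a saturated ring carbon gave a number 1.32 log units lower from compound 2 to compound 4 (beyond the scatter) in this assay and so matched the earlier a number 1.32 log units lower from compound 3 to compound 1 (beyond the scatter) at the digits printed, which means that this step carried over between the two cores, one with a methoxycarbonyl group and the other with an ethoxycarbonyl group. Going by these compounds alone, these are only two pairs, so they show a match and not a general rule, and they say nothing about how the same change would behave in any other core. Nothing available here accounts for the size of the step or for the match between the two pairs.

From the compounds shown here alone, it remains open whether a similar step would follow with another group on that saturated ring carbon, such as ethyl, a longer chain or an amine. Going by these compounds, it also remains open whether the step would keep its size in a core with a carboxylic acid in place of the methoxycarbonyl group.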